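Changing the carbonyl substituent: compound 3 to compound 4

The source may report more compounds than this note shows. Statements on the series, on what has been measured and on what is new or still open speak of the compounds shown alone.

In a functional assay (aorta) with Rattus norvegicus as the target (a higher number here means that more compound is needed for the effect, a lower number that less compound is needed), compound 1 `C/N=C(/NC)Nc1nc(-c2ccc(OC)cc2)c(-c2ccc(OC)cc2)s1` gives 2.4 uM, compound 2 `CNC(=O)NCc1nc(-c2ccc(OC)cc2)c(-c2ccc(OC)cc2)s1` gives 15 uM and compound 3 `CCN(CC)C(=O)c1nc(-c2ccc(OC)cc2)c(-c2ccc(OC)cc2)s1` gives 14 uM. Compound 3 therefore stands level with compound 2, and both have higher numbers than compound 1. Compound 4 `COc1ccc(-c2nc(C(=O)N3CCCCC3CCO)sc2-c2ccc(OC)cc2)cc1` has 2-(2-hydroxyethyl)piperidin-1-yl in place of diethylamino on a carbonyl carbon. Among the measured compounds shown here, no measured step changes this group alone. The nearest evidence is a 1.1-fold lower number from compound 2 to compound 3 (0.03 log units; within the scatter) and a 5.8-fold higher number from compound 1 to compound 3 (0.77 log units; beyond the scatter), and both replace a whole group on an aromatic carbon. Only a weak guide follows, so no step beyond the scatter is expected in this assay. The estimated step is a 1.4-fold lower number from compound 3 to compound 4 (0.15 log units; within the scatter), with its direction uncertain. For compound 4 the expected value is 10 uM, with an estimated range of 3 uM to 35 uM.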

Compound 4, concentration for half-maximal effect: 6.8 uM
For compound 4 the middle estimate is 1.5-fold (0.17 log units) above the measured one; the range from low to high includes it.
By their numbers in this assay, from the lowest: compound 1; then compound 4; then compounds 3 and 2 (each within the scatter of the next).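

In this assay, the carbonyl position gives its first direct reading: 2-(2-hydroxyethyl)piperidin-1-yl in place of diethylamino gives a 2.1-fold lower number from compound 3 to compound 4 (0.31 log units; beyond the scatter). The step is modest, but it shows that a larger group with one six-membered non-aromatic ring and a hydrogen-bond donor is accepted on this carbonyl carbon without a higher number. No measurement here accounts for the step.

As far as these compounds go, whether the ring or the 2-hydroxyethyl chain carries the change remains open. Unsubstituted piperidin-1-yl and a chain ending in a methoxy group or an amine would separate the two.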